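The compounds below may be only part of what the source reports. "The series", "measured", "known", "first", "only" and "open" are said of these compounds alone.

The two compounds already measured share one core and differ in two places at once. Compound 1, `CCCOCNc1n[n+]([O-])c2cc(OC)ccc2[n+]1[O-]`, carries a propoxymethyl chain on the amino nitrogen and a methoxy group on the carbocyclic ring; in a functional assay on SMMC-7721 cells (Homo sapiens) for cytotoxicity, read by MTT assay, with a stated time of 72 h (a higher number here means a weaker inhibitor, a lower number a stronger inhibitor), compound 1 gives 2880 nM. Compound 2, `COCNc1n[n+]([O-])c2ccccc2[n+]1[O-]`, has a shorter methoxymethyl chain and no methoxy on the ring, and in this assay compound 2 gives 6670 nM. Of the two numbers, compound 1 shows the lower one, and the gap to compound 2 lies beyond the usual scatter. Because the two compounds differ in two places, the numbers alone do not tell which change carries the difference.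

Compound 3, `CCCOCNc1n[n+]([O-])c2ccccc2[n+]1[O-]`, separates the two. It keeps the propoxymethyl chain of compound 1 and differs from it only in one place: hydrogen in place of methoxy on an aromatic carbon. Among the compounds with values here, no measured pair shows this change by itself, so the size of its effect is open. Taking the values of compound 1 and compound 2 as the only guide, a modest step upward, possibly within the scatter, is expected a 1.5-fold higher number from compound 1 to compound 3 (0.16 log units; within the scatter) for compound 3. Compound 3 is therefore estimated at 4200 nM, with a range from 2000 nM to 9000 nM.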

Compound 3, half-maximal inhibitory concentration: 19500 nM
For compound 3 the middle estimate is 4.6-fold (0.67 log units) below the measured one; measured number outside the range, above it.
By their numbers in this assay, from the lowest: compound 1; then compound 2; then compound 3.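

In this assay, within the data shown here, hydrogen in place of methoxy on the aromatic carbon that is meta to a fused ring and para to a fused ring gives a 6.8-fold higher number from compound 1 to compound 3 (0.83 log units; beyond the scatter), which isolates the effect of this ring position for the first time and shows that, with the propoxymethyl chain held constant, the methoxy group goes with the lower number. The new compound also isolates the chain: ethyl in place of hydrogen on the saturated chain carbon bound to an oxygen gives a 2.9-fold higher number from compound 2 to compound 3 (0.47 log units; beyond the scatter), so on the ring without methoxy the propoxymethyl chain goes with a higher number than the methoxymethyl chain, and the two changes that were mixed in the first pair run in opposite directions. The compounds shown offer no measurement that explains either step.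

On these data alone, it remains open whether the methoxy group brings a similar step when the chain is methoxymethyl, since each step has been seen in only one setting. As far as these compounds go, it is also open how an amine, a hydroxyl group or a chlorine atom on this aromatic carbon, or a butoxymethyl chain on the amino nitrogen, would read in this assay.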